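This account rests on a few compounds, and the source may have more. Where it says the series, first, only, none or still open, it means among the compounds named here.

Working notes on the piperidinyl urea series, solubility.

Three compounds carry the shared urea–piperidine core with differing amide caps. In a physicochemical assay for solubility, read by mass spectrometry, in phosphate buffer, with a stated time of 24 h, at pH 7.4 (a higher number here means a more soluble compound, a lower number a less soluble compound), compound 1 `Cc1ccoc1C(=O)N1CCC(NC(=O)Nc2ccc(C(F)(F)F)cc2)CC1` gives 0.8 ug/mL, compound 2 `O=C(Nc1ccc(C(F)(F)F)c(F)c1)NC1CCN(C(=O)C2(C(F)(F)F)CC2)CC1` gives 0.08 ug/mL, and compound 3 `O=C(Nc1ccc(OC(F)(F)F)c(F)c1)NC1CCN(C(=O)N2CCOCC2)CC1` gives 96 ug/mL. Compound 2 stands lowest of the three numbers: compound 1 is nearest, with a gap beyond the scatter, and compound 3 is furthest, beyond the scatter by a wide margin.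

Compound 4 `O=C(Nc1ccc(C(F)(F)F)c(F)c1)NC1CCN(C(=O)[C@@H]2CCOC2)CC1` has not yet been measured in this assay. It differs from compound 2 in one place: oxolan-3-yl in place of 1-(trifluoromethyl)cyclopropyl on a carbonyl carbon. The 1-(trifluoromethyl)cyclopropyl group leaves and oxolan-3-yl enters on the carbonyl carbon whose other neighbour is the amide-type nitrogen in the ring; three fluorines go out, one ring oxygen comes in as a hydrogen-bond acceptor.

Within the data shown here, no measured pair isolates this change. Given that compound 2 gives 0.08 ug/mL, the lowest number here, the step from compound 2 to compound 4 is expected to be upward and beyond the scatter, a 38-fold higher number from compound 2 to compound 4 (1.57 log units; beyond the scatter). Compound 4 is estimated at 3 ug/mL, within a range of 0.5 ug/mL to 15 ug/mL.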

Compound 4, solubility: 1.9 ug/mL
Compound 4: the middle estimate sits 1.6-fold (0.20 log units) above what was measured; measured number inside the range.
By their numbers in this assay, from the lowest: compound 2; then compound 1; then compound 4; then compound 3.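

The change to oxolan-3-yl in place of 1-(trifluoromethyl)cyclopropyl on a carbonyl carbon gives a 24-fold higher number from compound 2 to compound 4 (1.38 log units; beyond the scatter) in this assay, a large step. Among these compounds, this is the first step with only one place changed, which shows that this position alone can move the read-out well beyond the scatter. No data at hand separate the three fluorines leaving from the ring oxygen entering, and none account for the step.

Still open, going by these compounds, is how an open-chain ether such as 2-methoxyethyl, a tertiary amine or a carboxylic acid on this carbonyl carbon would read in this assay, and whether the opposite stereoisomer of oxolan-3-yl would read the same. Also open, on these data alone, is whether the step carries over to the aryl groups of compound 1 and compound 3.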